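Three Sulfonyl Hydroxyguanidines and a Trimethoxy Benzyl Swap

This account rests on a few compounds, and the source may have more. Where it says the series, first, only, none or still open, it means among the compounds named here.

Of the compounds shown here, three sharing one core have been tested in a functional assay on UO-31 cells (Homo sapiens); on this read-out lower numbers stand for stronger inhibition of growth and higher numbers for weaker inhibition of growth. Compound 1 `COc1cc(CSc2cc(Cl)c(-c3nnc(-c4ccccc4)s3)cc2S(=O)(=O)NC(=N)NO)cc(OC)c1OC` gives 3980 nM. Among the compounds with values here, compound 2 `COc1cc(CSc2cc(Cl)c(-c3nc(-c4ccc(Cl)cc4)no3)cc2S(=O)(=O)NC(=N)NO)cc(OC)c1OC` gives 3160 nM, and the only single-point step among the measured compounds, a 1.3-fold lower number from compound 1 to compound 2 (0.10 log units; within the scatter), changes nothing beyond the scatter. Compound 3 `N=C(NO)NS(=O)(=O)c1cc(-c2nnc(-c3ccc(Cl)cc3)s2)c(Cl)cc1SCc1ccccc1` gives 1990 nM; this is the lowest of the three numbers, yet its gaps to compound 2 and to compound 1 both fall within the scatter, so the three compounds cannot be ranked.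

Compound 4 `COc1cc(CSc2cc(Cl)c(-c3nnc(-c4ccc(Cl)cc4)s3)cc2S(=O)(=O)NC(=N)NO)cc(OC)c1OC` has not been measured. It differs from compound 3 in one place: 3,4,5-trimethoxyphenyl in place of phenyl on a saturated chain carbon bound to a sulfur. Within the data shown here, no measured step probes this particular change, since compound 1 and compound 3 differ in two places at once, so the step between them cannot be assigned to either change alone. Among the measured compounds shown here, the one step that is known, from compound 1 to compound 2, concerns a different part of the molecule and was within the scatter.

For the measured compounds named here, with no direct precedent, compound 4 is expected to stay close to compound 3, the estimated step being a 1.5-fold higher number from compound 3 to compound 4 (0.18 log units; within the scatter). The estimate for compound 4 in this assay is 3000 nM, with a range from 1200 nM to 7500 nM.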

Compound 4, concentration for 50% growth inhibition: 44700 nM
Compound 4: the middle estimate sits 15-fold (1.17 log units) below what was measured; measured number outside the range, above it.
By their numbers in this assay, from the lowest: compounds 3, 2 and 1 (each within the scatter of the next); then compound 4.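

In this assay, within the data shown here, 3,4,5-trimethoxyphenyl in place of phenyl on a saturated chain carbon bound to a sulfur gives a 22-fold higher number from compound 3 to compound 4 (1.35 log units; beyond the scatter), so this position, which no earlier step probed, is far from indifferent to the group it carries. The two other single changes that lead to compound 4 are large as well: 5-(4-chlorophenyl)-1,3,4-thiadiazol-2-yl in place of 3-(4-chlorophenyl)-1,2,4-oxadiazol-5-yl on an aromatic carbon gives a 14-fold higher number from compound 2 to compound 4 (1.15 log units; beyond the scatter), and chloro in place of hydrogen on an aromatic carbon gives an 11-fold higher number from compound 1 to compound 4 (1.05 log units; beyond the scatter). Compound 1 and compound 2 carry the same 3,4,5-trimethoxyphenyl group, so that group does not go with a high number by itself in this set, and the high number appears only in the particular combination found in compound 4.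

Nothing available explains why this combination behaves so differently. Going by these compounds, it also remains open whether a single methoxy group on the phenyl ring, or a plain hexyl chain on the same carbon, would behave like compound 3 or like compound 4.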